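Chloro for Bromo: Compound 2 to Compound 4

The source may report more compounds than this note shows. Statements on the series, on what has been measured and on what is new or still open speak of the compounds shown alone.

Compound 1, `CCOC(=O)C1=Cc2ccccc2OC1(OCc1cn(CC(=O)Nc2ccccc2F)nn1)C(F)(F)F`: in a functional assay on A549 cells (Homo sapiens) for inhibition, read by MTT assay, with a stated time of 24 h (a lower number here means a stronger inhibitor, a higher number a weaker inhibitor), compound 1 gives 50100 nM.
Compound 2, `CCOC(=O)C1=Cc2ccccc2OC1(OCc1cc(-c2ccc(Br)cc2)no1)C(F)(F)F`: in this assay compound 2 gives > 150000 nM, which is a limit of the assay and not a number.
Compound 3, `CCOC(=O)C1=Cc2ccccc2OC1(OCc1cn(-c2ccccc2)nn1)C(F)(F)F`: in this assay compound 3 gives > 150000 nM, again a limit of the assay.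

Compound 2 therefore stands only at a limit, with no measured number of its own; the same is true of compound 3, as the limit of > 150000 nM in this assay, at which 2 of the 3 values shown sit, records. Compound 4, `CCOC(=O)C1=Cc2ccccc2OC1(OCc1cc(-c2ccc(Cl)cc2)no1)C(F)(F)F`, has not yet been measured. It differs from compound 2 by chloro in place of bromo on an aromatic carbon.

Among the measured compounds shown here, the one measured step in this set, an at least 2.9-fold higher number from compound 1 to compound 3 (0.47 log units; beyond the scatter), concerns a different position and a different kind of group, so it does not bear on a change of one halogen for another on the six-membered aromatic ring. For the measured compounds named here, no measured step speaks to the bromo-to-chloro exchange, and nothing among the three compounds suggests a movement beyond the scatter.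

The expectation is therefore that compound 4 behaves like compound 2 in this assay, most likely returning the same limit, with an estimated 150000 nM, in the range 75000 nM to 300000 nM. The step this estimate implies is expected to be a number no higher from compound 2 to compound 4 (the limit leaves the size open), which is no step beyond the scatter.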

Compound 4, half-maximal inhibitory concentration: 19100 nM
For compound 4 the middle estimate is 7.9-fold (0.90 log units) above the measured one; the whole stated range lies above it.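

Exchanging one halogen for the other at this place, on an aromatic carbon para to a large group, does matter in this assay: replacing 4-bromophenyl with 4-chlorophenyl gives an at least 7.8-fold lower number from compound 2 to compound 4 (0.89 log units; beyond the scatter). Among the compounds shown here, the earlier compounds held no step at this place, since the only one available, an at least 2.9-fold higher number from compound 1 to compound 3 (0.47 log units; beyond the scatter), concerned the group on an aromatic nitrogen, so this is the first sign that the substituent on this six-membered aromatic ring can separate two compounds that are otherwise identical. Compound 2 gives > 150000 nM, which is a limit of the assay and not a number, so the true size of the step remains unknown, and compound 2 shares that limit with one other compound: the limit of > 150000 nM in this assay, at which 2 of the 4 values shown sit.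

The compounds shown leave open whether another group on the same aromatic carbon, such as fluoro, methoxy or an amine, would lower the number further or return it to the limit. They also leave open whether a chloro on the phenyl of compound 3 would bring that compound away from its limit, or whether this effect is confined to the 4-chlorophenyl group of compound 4.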